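From Chloro to Methoxy on a Shared Core

A few compounds are considered here, and "the series" means these few. Any claim that something is new, unique, unknown or untested is made for them only; others in the source may bear on it.

compound 1 `COc1ccc(NC(=O)Nc2c(C)[n+]([O-])c3ccc(OC)cc3[n+]2[O-])cc1` — > 10 ug/mL
compound 2 `Cc1c(NC(=O)OC(C)C)[n+]([O-])c2cc(Cl)ccc2[n+]1[O-]` — > 10 ug/mL

In a functional assay on U-251 cells (Homo sapiens) for inhibition, read by sulforhodamine B assay, with a stated time of 48 h (a lower number here means a stronger inhibitor, a higher number a weaker inhibitor), compound 1 `COc1ccc(NC(=O)Nc2c(C)[n+]([O-])c3ccc(OC)cc3[n+]2[O-])cc1` gives > 10 ug/mL, which is a limit of the assay rather than a number. Compound 2 `Cc1c(NC(=O)OC(C)C)[n+]([O-])c2cc(Cl)ccc2[n+]1[O-]` is likewise reported only as a limit in this assay, at > 10 ug/mL. Both measured values therefore sit at the limit of > 10 ug/mL in this assay, at which 2 of the 2 values shown sit, so nothing can be said about how the two compounds compare with each other, and compound 2 stands at the edge of what this assay reports.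

Compound 3 `COc1ccc2c(c1)[n+]([O-])c(NC(=O)OC(C)C)c(C)[n+]2[O-]` has not yet been tested. It differs from compound 2 in one place: methoxy in place of chloro on an aromatic carbon. Compound 1 also carries a methoxy group on its ring and sits at a limit, so nothing here points to a gain. The step that the limit leaves unreadable from compound 2 to compound 3 is expected to be none beyond the usual scatter, with compound 3 most likely again reported as a limit. Compound 3 is estimated at 15 ug/mL, within a range from 5 ug/mL to 50 ug/mL.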

Compound 3, half-maximal inhibitory concentration: > 10 ug/mL
Compound 3 ended at the assay's limit (the forecaster's own chance of this, stated with the estimate: 80%); the middle value lies beyond the limit too.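

Compound 3 is also reported only as a limit, so no step can be read between compound 1, compound 2 and compound 3, and all three sit together: the limit of > 10 ug/mL in this assay, at which 3 of the 3 values shown sit.

What the compounds shown leave open is how strongly any of them inhibits, and whether methoxy in place of chloro changes anything.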